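The source may hold more compounds than are shown below. What is called first, only, known or untested is meant among the compounds shown, and "the series" means these compounds.

Of the compounds shown here, three sharing one core have been tested in a functional assay on MCF7 cells (Homo sapiens) for antiproliferative activity, read by sulforhodamine B assay, with a stated time of 72 h, tested at 30 uM; a higher number here means a weaker effect of the compound at the concentration tested, a lower number a stronger effect. Compound 1 `COc1cc(Br)cc(/C=C/C(=O)c2ccccc2)c1O` gives 28.1%, compound 3 `COc1cc(Cl)cc(/C=C/C(=O)c2ccc(Br)cc2)c1O` gives 26.3%, and compound 2 `COc1cccc(C(=O)/C=C/c2cc(Br)cc(OC)c2O)c1` gives 63.1%, the highest of the three numbers and so the weakest effect at this concentration. Going by the values given here, the only single-point step among them, a number 35 percentage points higher from compound 1 to compound 2 (beyond the scatter), is large. Compound 4 `COc1cccc(C(=O)/C=C/c2cc(Br)ccc2O)c1` differs from compound 2 by hydrogen in place of methoxy on an aromatic carbon, ortho to a hydroxy group and meta to a bromo group. Among the compounds with values here, no measured step bears directly on this change: the step from compound 1 to compound 2 concerns a methoxy on the other ring, and compounds 1 and 3 both keep this methoxy. The change is therefore expected to be modest in size and uncertain in direction, a number 11.1 percentage points lower from compound 2 to compound 4 (beyond the scatter). Compound 4 is estimated at 52%, within 25% to 80%.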

Compound 4, a percentage reported as activity, at one concentration (the size of the read-out at that concentration, not a potency): 28.3%
The estimate for compound 4 lay 23.7 percentage points above the measured number, and the stated range covers the measured number.
By their numbers in this assay, from the lowest: compounds 3, 1 and 4 (each within the scatter of the next); then compound 2.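

In this assay, going by these compounds alone, the earlier compounds all kept the methoxy ortho to a hydroxy group and meta to a bromo group, so they could not show whether this position matters. Replacing it with hydrogen gives a number 34.8 percentage points lower from compound 2 to compound 4 (beyond the scatter), a clearly stronger effect at the concentration tested, so this position is sensitive to the change. Nothing available explains this shift.

On these data alone, how other groups behave on this carbon remains open, such as an amine, a fluoro group or an ethoxy group. Also open, as far as these compounds go, is whether this step keeps its size without the methoxy on the other ring.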